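The source may report more compounds than this note shows. Statements on the series, on what has been measured and on what is new or still open speak of the compounds shown alone.

In a functional assay on HeLa cells (Homo sapiens) for inhibition, read by CCK-8 assay, with a stated time of 72 h, tested at 2 uM (on this read-out lower numbers stand for less inhibition of growth and higher numbers for more inhibition of growth at the one concentration tested), compound 1 (`Nc1ccccc1NC(=O)/C=C/c1ccc(CSc2cccc(F)c2)cc1`) gives 2.25%, the lower of the two numbers available. Compound 2 (`CCc1ccc(SCc2ccc(C(=O)Nc3ccccc3N)cc2)cc1`) gives 30.8%, beyond the scatter above it. Compound 3 (`CC(C)(C)c1ccc(SCc2ccc(/C=C/C(=O)Nc3ccccc3N)cc2)cc1`) carries 4-(tert-butyl)phenyl in place of 3-fluorophenyl on a sulfur. Within the data shown here, no measured pair shows this change on its own, so the expectation rests on little. A small rise in this assay, not clearly beyond the scatter, is expected, an estimated a number 9.8 percentage points higher from compound 1 to compound 3 (within the scatter). For compound 3 the estimated value is 12%, with an expected range of 0% to 35%.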

Compound 3, percent growth inhibition at one concentration: 17.5%
The estimate for compound 3 lay 5.5 percentage points below the measured number; the measured number falls inside the stated range.
By their numbers in this assay, from the lowest: compound 1; then compound 3; then compound 2.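

Among these compounds, on the sulfur whose other neighbour is a saturated chain carbon, the aryl group matters in this assay: 4-(tert-butyl)phenyl in place of 3-fluorophenyl gives a number 15.3 percentage points higher from compound 1 to compound 3 (beyond the scatter) and so provides the first single-place change that can be read. The earlier compounds shown here could not show this, since they differ in more than one place. As far as these compounds go, it remains open whether gaining the tert-butyl group or losing the fluorine drives the step, and whether a phenyl bearing an amine or a carboxylic acid would read differently. No available evidence accounts for this step.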